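The compounds below may be only part of what the source reports. "The series", "measured", "known", "first", "only" and "open" are said of these compounds alone.

Measured so far in an assay on isolated protein for inhibition of Maltase-glucoamylase (Homo sapiens), with a stated time of 15 min; a lower number here means a stronger inhibitor, a higher number a weaker inhibitor:

compound 1 `O=C(N/N=C/c1ccc(O)cc1)c1ccc(-c2nc3ccccc3s2)cc1`: 11300 nM
compound 2 `O=C(N/N=C/c1ccc(O)c(O)c1)c1ccc(-c2nc3ccccc3s2)cc1`: 15100 nM

Compound 2 holds the higher of the two numbers in this assay, with compound 1 nearest; the step of a 1.3-fold higher number from compound 1 to compound 2 (0.13 log units; within the scatter) does not separate the two. Compound 3 `COc1cc(/C=N/NC(=O)c2ccc(-c3nc4ccccc4s3)cc2)cc(OC)c1` is the next member, differing from compound 2 by 3,5-dimethoxyphenyl in place of 3,4-dihydroxyphenyl on a carbon with a double bond to nitrogen. Within the data shown here, only one measured step touches this ring, the one from compound 1 to compound 2, and it stayed within the scatter, so no step beyond the scatter is expected here, estimated as a 1.1-fold lower number from compound 2 to compound 3 (0.03 log units; within the scatter). Compound 3 is therefore expected to give about 14000 nM in this assay, with a range from 5000 nM to 40000 nM.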

Compound 3, half-maximal inhibitory concentration: 16200 nM
Compound 3: the middle estimate sits 1.2-fold (0.06 log units) below what was measured; the measured number falls inside the stated range.
By their numbers in this assay, from the lowest: compounds 1, 2 and 3 (each within the scatter of the next).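

In this assay, 3,5-dimethoxyphenyl in place of 3,4-dihydroxyphenyl on the carbon with a double bond to nitrogen gives a 1.1-fold higher number from compound 2 to compound 3 (0.03 log units; within the scatter), and in place of 4-hydroxyphenyl it gives a 1.4-fold higher number from compound 1 to compound 3 (0.16 log units; within the scatter). This position therefore tolerates a ring with 0 hydrogen-bond donors and 10 heavy atoms without any step beyond the scatter. No supporting data bear on why these steps stay so small.

On these data alone, whether an amine or a carboxylic acid on this ring would give a step beyond the scatter remains open. Changes to the shared core also remain untested here.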